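From methylamino to phenyl: a step beyond a limit

The source may report more compounds than this note shows. Statements on the series, on what has been measured and on what is new or still open speak of the compounds shown alone.

Measured in a functional assay on MCF7 cells (Homo sapiens), read by colorimetric assay, with a stated time of 96 h; on this read-out lower numbers stand for stronger inhibition and higher numbers for weaker inhibition:
Compound 1 `OC[C@@H](O)[C@H]1O[C@@H](n2cnc3c(Cl)ncnc32)[C@H](O)[C@@H]1O`: > 100000 nM (a limit)
Compound 2 `CNc1ncnc2c1ncn2[C@@H]1O[C@H]([C@H](O)CO)[C@@H](O)[C@H]1O`: > 100000 nM (a limit)
Compound 3 `CNc1nc(Cl)nc2c1ncn2[C@@H]1O[C@H]([C@H](O)CO)[C@@H](O)[C@H]1O`: > 100000 nM (a limit)

In this assay compound 2 gives > 100000 nM, which is a limit and not a number. The other two measured compounds also give only limits, so no order among the three can be told. The whole of the evidence is the limit of > 100000 nM in this assay, at which 3 of the 3 values shown sit.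

Compound 4 `OC[C@@H](O)[C@H]1O[C@@H](n2cnc3c(-c4ccccc4)ncnc32)[C@H](O)[C@@H]1O` keeps the shared core and changes one group: phenyl in place of methylamino on an aromatic carbon. Within the data shown here, two measured steps bear on this change. One is a step that the two limits leave unreadable from compound 1 to compound 2, made at the same carbon. The other is a step that the two limits leave unreadable from compound 2 to compound 3, made elsewhere on the core. Neither has a size that can be carried over, so any expectation here is a weak one.

With compound 2 held at > 100000 nM, compound 4 is expected to stay weak in this assay. The expected step is an at least 1.4-fold lower number from compound 2 to compound 4 (0.15 log units; that floor lies within the scatter), small and towards stronger inhibition, and only a limit may come back again. For compound 4 the estimated value is 70000 nM, with an expected range from 15000 nM to 200000 nM.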

Compound 4, half-maximal inhibitory concentration: > 100000 nM
Compound 4 gave a limit, no number; the forecaster's own chance of this, stated with the estimate: 60%; middle value at least 1.4-fold (0.15 log units) from the limit.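

In this assay compound 4 gives > 100000 nM, which is a limit and not a number. The steps to compound 4 from compound 1 and compound 2 therefore cannot be read. The compounds shown leave open how phenyl, methylamino and chloro on this carbon truly compare.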